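A Hydroxy Group on the Aromatic Ring of Compound 3

A few compounds are considered here, and "the series" means these few. Any claim that something is new, unique, unknown or untested is made for them only; others in the source may bear on it.

Compound 3 `CC1=CC[C@H](C(C)(C)NC(=S)N/N=C/c2ccccc2)CC1` is the more potent of the two compounds that give a number here. In a functional assay on PC-3 cells (Homo sapiens) for inhibition, read by sulforhodamine B assay, with a stated time of 48 h (a higher number here means a weaker inhibitor of growth, a lower number a stronger inhibitor of growth), compound 3 gives 1300 nM. Compound 2 `CC1=CC[C@H](C(C)(C)NC(=S)NN)CC1` gives 44500 nM in this assay, so compound 3 stands lowest of the two numbers in hand. Compound 1 `CC1=CC[C@H](C(C)(C)N=C=S)CC1` sits at the limit of > 100000 nM in this assay, at which 1 of the 3 values shown sits, a limit and not a number. In this assay compound 1 is recorded only as > 100000 nM, a limit of the assay.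

For the measured compounds named here, the single measured step, an at least 2.2-fold lower number from compound 1 to compound 2 (0.35 log units; beyond the scatter), concerns the group on the chain carbon of the shared core and says nothing about what happens on the aromatic ring of compound 3.

Compound 4 `CC1=CC[C@H](C(C)(C)NC(=S)N/N=C/c2ccc(O)cc2)CC1` differs from compound 3 by hydroxy in place of hydrogen on an aromatic carbon. Going by the values given here, no measured step bears on a change of this kind, so the expectation rests on compound 3 alone, which gives 1300 nM in this assay. The step from compound 3 to compound 4 is therefore expected to stay within the scatter, in no particular direction, as a 1.2-fold lower number from compound 3 to compound 4 (0.07 log units; within the scatter). Compound 4 is estimated at 1100 nM in this assay, with a range from 300 nM to 4000 nM.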

Compound 4, concentration for 50% growth inhibition: 600 nM
Compound 4: middle estimate off by 1.8-fold (0.26 log units), on the high side, and the stated range covers the measured number.
By their numbers in this assay, from the lowest: compound 4; then compound 3; then compound 2. At a limit, above all of these: compound 1.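

Read in this assay the change on the aromatic ring gives a 2.2-fold lower number from compound 3 to compound 4 (0.34 log units; beyond the scatter) for hydroxy in place of hydrogen, para to a large group. For the compounds shown here, the earlier step concerned only the group on the chain carbon of the shared core, so this is the first measured sign that the aromatic ring of compound 3 accepts a new group and that phenyl to 4-hydroxyphenyl moves the number beyond the scatter, modestly, toward stronger inhibition of growth. Nothing on record here bears on what lies behind this step.

What a methoxy group, a fluorine atom or an amine would do at this same place stays open, so the compounds shown cannot tell whether the gain is particular to hydroxy or would come with other groups there as well. Also open, on these data alone, is whether hydroxy on another carbon of the ring, or a second hydroxy added to the first, would lower the number further or give back what this one change gained.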